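The source may report more compounds than this note shows. Statements on the series, on what has been measured and on what is new or still open speak of the compounds shown alone.

Compound 1, `CN[C@@H]1CCN(c2c(F)cc3c(=O)c(C(=O)O)cn(Cc4ccc(-c5ccccc5)cc4)c3c2OC)C1`, gives 57700 nM in an assay on isolated protein for inhibition of DNA topoisomerase 1 (Homo sapiens), with a stated time of 15 min; a lower number here means a stronger inhibitor, a higher number a weaker inhibitor. Compound 2, `COc1c(N2CC[C@@H](N)C2)c(F)cc2c(=O)c(C(=O)O)cn(Cc3ccc(-c4ccccc4)cc3)c12`, gives 92200 nM in this assay, and the step of a 1.6-fold higher number from compound 1 to compound 2 (0.20 log units; within the scatter) shows that the two numbers cannot be told apart. Within the data shown here, compound 2 thus stands at a number that sits within the scatter of compound 1, the only other number available, so neither can be called the weaker or the stronger inhibitor.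

Compound 3, `CNCCCNc1c(F)cc2c(=O)c(C(=O)O)cn(Cc3ccc(-c4ccccc4)cc3)c2c1OC`, is not yet measured. It differs from compound 2 by (3-(methylamino)propyl)amino in place of 3-aminopyrrolidin-1-yl on an aromatic carbon. Among the measured compounds shown here, no measured step bears directly on this change: the one step in hand, from methyl to hydrogen on an amine nitrogen, touched only the substituent on the ring that now leaves, and it stayed within the scatter. The change from compound 2 to compound 3 is of a different kind, so the direction cannot be read from the two numbers. On that basis compound 3 is expected to give 80000 nM in this assay, with a range of 25000 nM to 250000 nM, which means an expected step of a 1.2-fold lower number from compound 2 to compound 3 (0.06 log units; within the scatter), not clearly beyond the scatter.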

Compound 3, half-maximal inhibitory concentration: 101000 nM
Estimate against measurement, compound 3: 1.3-fold (0.10 log units) below, within the range that was stated.
By their numbers in this assay, from the lowest: compounds 1, 2 and 3 (each within the scatter of the next).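

In this assay, (3-(methylamino)propyl)amino in place of 3-aminopyrrolidin-1-yl on the aromatic carbon ortho to a fluoro group and ortho to a methoxy group gives a 1.1-fold higher number from compound 2 to compound 3 (0.04 log units; within the scatter), and the same chain in place of 3-(methylamino)pyrrolidin-1-yl gives a 1.8-fold higher number from compound 1 to compound 3 (0.24 log units; within the scatter) in the same assay. The earlier pair had tested only a methyl on the amine nitrogen of the ring, whereas these two steps replace the whole five-membered non-aromatic ring and its defined stereocentre with an open chain, and the numbers still cannot be told apart, so none of the three compounds can be called the stronger or the weaker inhibitor. The data offer no measured explanation for this result.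

As far as these compounds go, whether a piperazine ring, a longer chain such as a butyl link between the two nitrogens, or a group with no amine at all at this position would move the number beyond the scatter remains open. From the compounds shown here alone, all three compounds also carry the same methoxy group, so the effect of an ethoxy group or a hydrogen in its place is unknown.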